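The source may report more compounds than this note shows. Statements on the series, on what has been measured and on what is new or still open speak of the compounds shown alone.

Of the compounds shown here, two have so far been tested in a functional assay on the whole organism (strain albino) for inhibition, with Rattus norvegicus as the target, read by paw edema, with stated times of 1 h and 3 h, at a dose of 100 mg/kg by the oral route; on this read-out higher numbers stand for a stronger effect at the one dose given and lower numbers for a weaker effect. Compound 2 `Cn1c(SCC(=O)Nn2c(COc3ccc(Cl)cc3Cl)nc3ccccc3c2=O)nc(-c2ccc(Cl)cc2)c(C#N)c1=O` gives 73.7% in this assay. Within the data shown here, compound 1 `N#Cc1c(-c2ccc(O)cc2)nc(SCC(=O)Nn2c(COc3ccc(Cl)cc3Cl)nc3ccccc3c2=O)[nH]c1=O` gives 68.4% in this assay, and the two numbers lie within the usual scatter of each other, so compound 2 stands level with the only other measured compound rather than apart from it. Compound 3 `Cn1c(SCC(=O)Nn2c(COc3ccc(Cl)cc3Cl)nc3ccccc3c2=O)nc(-c2ccc(O)cc2)c(C#N)c1=O` has not yet been measured. Among the measured compounds shown here, it differs from compound 2 in one place: hydroxy in place of chloro on an aromatic carbon No step between two measured compounds that differ only in this way is available, since compound 1 also differs from compound 3 elsewhere. Compound 3 is nevertheless expected to shift by only a number 5.7 percentage points lower from compound 2 to compound 3 (within the scatter), a step not beyond the scatter, because compound 1 gives 68.4% while carrying the same 4-hydroxyphenyl group. Compound 3 is estimated at 68% in this assay, with a likely range from 50% to 82%.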

Compound 3, a percentage reported as inhibition, in the whole organism at one dose (the size of the read-out at that dose, not a potency): 86%
Compound 3: middle estimate off by 18 percentage points, on the low side, outside the stated range (above it).
By their numbers in this assay, from the lowest: compounds 1 and 2 (each within the scatter of the next); then compound 3.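

In this assay the change from 4-chlorophenyl to 4-hydroxyphenyl gives a number 12.3 percentage points higher from compound 2 to compound 3 (beyond the scatter) and so shows that this place on the aromatic ring matters: with the methyl on the aromatic nitrogen kept, hydroxy gives the higher number here. Methyl in place of hydrogen on that nitrogen, with the 4-hydroxyphenyl group kept, gives a number 17.6 percentage points higher from compound 1 to compound 3 (beyond the scatter) and so shows that the hydroxy group alone does not bring the highest number among these compounds. No measurement shown here accounts for either step.

On these data alone, whether an amine or a methoxy group at the same ring place would match hydroxy, and whether a longer chain such as ethyl on the nitrogen would keep the number, remains open. As far as these compounds go, each number also comes from a single dose, so it shows a stronger or weaker effect at that dose only, and how these compounds compare at other doses remains open too.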